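One change on the amide-type nitrogen

A few compounds are considered here, and "the series" means these few. Any claim that something is new, unique, unknown or untested is made for them only; others in the source may bear on it.

Compound 1 `COc1cc2c(cc1OC)C(=O)C(CC1CCN(C(=S)Nc3ccc(C)cc3)CC1)C2`: 30 mg/kg
Compound 2 `COc1cc2c(cc1OC)C(=O)C(CC1CCN(C(=S)Nc3ccc([N+](=O)[O-])cc3)CC1)C2`: 30 mg/kg

Both values come from a functional assay on the whole organism (strain Swiss albino) with Mus musculus as the target, in the maximal electroshock model, with a stated time of 0.5 h; a higher number here means that more compound is needed for the effect, a lower number that less compound is needed. Compound 2 stands level with compound 1 at the digits shown, and the only measured step, no change at the digits printed from compound 1 to compound 2 (within the scatter), stays within the scatter. Compound 3 `COc1cc2c(cc1OC)C(=O)C(CC1CCN(C(=S)Nc3ccccc3Cl)CC1)C2` differs from compound 2 by 2-chlorophenyl in place of 4-nitrophenyl on an amide-type nitrogen. For the measured compounds named here, no measured step covers this exact change: the single step known replaces methyl by nitro on an aromatic carbon and leaves the dose unchanged, which is the only hint that a change on this ring may pass without a visible effect. With nothing further to go on, compound 3 is expected to give 30 mg/kg, with a range from 15 mg/kg to 100 mg/kg. The step this estimate means, no change at the digits printed from compound 2 to compound 3 (within the scatter), is expected to stay within the scatter.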

Compound 3, minimum effective dose: 100 mg/kg
Beside the measured number, compound 3's estimate is 3.3-fold (0.52 log units) below it; measured number inside the range.
By their numbers in this assay, from the lowest: compounds 1 and 2 (each within the scatter of the next); then compound 3.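

In this assay, the group on the amide-type nitrogen proves able to move the dose: 2-chlorophenyl in place of 4-nitrophenyl gives a 3.3-fold higher number from compound 2 to compound 3 (0.52 log units; beyond the scatter), and 2-chlorophenyl in place of 4-methylphenyl gives a 3.3-fold higher number from compound 1 to compound 3 (0.52 log units; beyond the scatter). The earlier swap between 4-methylphenyl and 4-nitrophenyl had shown no visible change, so that quiet result does not hold for every ring at this position, and here more compound is needed with 2-chlorophenyl than with either of the other two. Nothing available explains why this ring behaves differently.

Going from either earlier ring to 2-chlorophenyl changes both the substituent and its place on the ring, so the two effects cannot yet be told apart. A 4-chlorophenyl or a plain phenyl group on the same nitrogen would help separate them.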